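Trading a Cyclopentyl Ring for a Methoxyethyl Chain

The source may hold more compounds than are shown below. What is called first, only, known or untested is meant among the compounds shown, and "the series" means these compounds.

In a functional assay (trachea) with Cavia porcellus as the target (on this read-out lower numbers stand for stronger inhibition and higher numbers for weaker inhibition), compound 1 (`Oc1nnc(-c2cccnc2)c2ccccc12`) gives 10200 nM. Compound 2 (`CCCn1nc(-c2cccnc2)c2ccccc2c1=O`), with propyl on an aromatic nitrogen, gives 3160 nM. Compound 3 (`O=c1c2ccccc2c(-c2cccnc2)nn1C1CCCC1`), with cyclopentyl at that place, gives 2750 nM. Compound 3 therefore stands level with compound 2 within the scatter, and its number is clearly lower than that of compound 1.

Compound 4 (`COCCn1nc(-c2cccnc2)c2ccccc2c1=O`) differs from compound 3 by a single change, 2-methoxyethyl in place of cyclopentyl on an aromatic nitrogen. Within the data shown here, one measured step bears on this change, a 1.1-fold lower number from compound 2 to compound 3 (0.06 log units; within the scatter). Replacing an open chain with a ring at this place thus made no difference beyond the scatter. Among the measured compounds shown here, no measured compound carries an oxygen in this group, so that step is only a rough guide. The step expected in this assay is a 1.1-fold higher number from compound 3 to compound 4 (0.04 log units; within the scatter), which means none beyond the scatter. For compound 4 the estimate is 3000 nM, with an expected range of 1200 nM to 8000 nM.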

Compound 4, half-maximal inhibitory concentration: 9330 nM
Estimate against measurement, compound 4: 3.1-fold (0.49 log units) below; the whole stated range lies below it.
By their numbers in this assay, from the lowest: compounds 3 and 2 (each within the scatter of the next); then compounds 4 and 1 (each within the scatter of the next).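

The earlier compounds shown here showed only that propyl and cyclopentyl on the aromatic nitrogen sit level, so this position could have seemed indifferent to the group it carries. The oxygen-bearing chain changes that: in this assay the switch from the ring gives a 3.4-fold higher number from compound 3 to compound 4 (0.53 log units; beyond the scatter) and the switch from the open chain, methoxy in place of methyl, gives a 3.0-fold higher number from compound 2 to compound 4 (0.47 log units; beyond the scatter) so inhibition weakens against both oxygen-free groups. Nothing here explains why the oxygen-bearing chain does worse.

Among these compounds, with only this one oxygen-bearing group, the result cannot show whether the oxygen's presence or its place along the chain matters. A longer chain such as 3-methoxypropyl, or an amine such as 2-aminoethyl, would help to separate these possibilities.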